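A few compounds are considered here, and "the series" means these few. Any claim that something is new, unique, unknown or untested is made for them only; others in the source may bear on it.

Measured compounds:
Compound 1 `COc1cc(C2=NOC(COc3ccc(-c4nnnn4-c4cc(OC)c(OC)c(OC)c4)cc3N)C2)cc(OC)c1OC`: 3230 nM
Compound 2 `COc1ccc(C2=NOC(COc3ccc(-c4nnnn4-c4cc(OC)c(OC)c(OC)c4)cc3N)C2)cc1O`: 3380 nM
Compound 3 `COc1ccc(F)c(C2=NOC(COc3ccc(-c4nnnn4-c4cc(OC)c(OC)c(OC)c4)cc3N)C2)c1`: 2830 nM

In a functional assay on MDA-MB-231 cells (Homo sapiens) for cytotoxicity, read by MTT assay, with a stated time of 48 h (on this read-out higher numbers stand for weaker inhibition and lower numbers for stronger inhibition), compound 3 gives 2830 nM, and all three numbers lie within the scatter of one another. Compound 3 therefore stands level with the other two measured compounds rather than apart from them.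

Compound 4 `COc1ccc(C2=NOC(COc3ccc(-c4nnnn4-c4cc(OC)c(OC)c(OC)c4)cc3N)C2)cc1[N+](=O)[O-]` has not yet been measured. It differs from compound 3 by one exchange, (4-methoxy-3-nitrophenyl in place of 2-fluoro-5-methoxyphenyl on a carbon with a double bond to nitrogen), with 4-methoxy-3-nitrophenyl in place of 2-fluoro-5-methoxyphenyl on a carbon with a double bond to nitrogen.

Three measured steps exchange the group at this same place: a 1.0-fold higher number from compound 1 to compound 2 (0.02 log units; within the scatter), a 1.1-fold lower number from compound 1 to compound 3 (0.06 log units; within the scatter) and a 1.2-fold lower number from compound 2 to compound 3 (0.08 log units; within the scatter). Each of them lies within the scatter, so this series has so far shown no measurable response to the exchange. For the measured compounds named here, none of the measured compounds carries the entering 4-methoxy-3-nitrophenyl group, however, so its own contribution remains untested, and the range has to stay fairly wide.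

On these three small steps, no change beyond the scatter is expected in this assay. The estimated step is a 1.1-fold higher number from compound 3 to compound 4 (0.03 log units; within the scatter). The estimate for compound 4 is 3000 nM, with an expected range from 1500 nM to 6000 nM.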

Compound 4, half-maximal inhibitory concentration: 3560 nM
Estimate against measurement, compound 4: 1.2-fold (0.07 log units) below; the measured number falls inside the stated range.
By their numbers in this assay, from the lowest: compounds 3, 1, 2 and 4 (each within the scatter of the next).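

With the first measured 4-methoxy-3-nitrophenyl group, the insensitivity seen so far at this place extends to a group with 11 heavy atoms and 3 hydrogen-bond acceptors, against 9 and 1 for the 2-fluoro-5-methoxyphenyl group it replaces: this assay gives a 1.3-fold higher number from compound 3 to compound 4 (0.10 log units; within the scatter) and, against the 3,4,5-trimethoxyphenyl compound, a 1.1-fold higher number from compound 1 to compound 4 (0.04 log units; within the scatter) as well. The narrowest exchange, nitro in place of hydroxy on an aromatic carbon, gives a 1.1-fold higher number from compound 2 to compound 4 (0.02 log units; within the scatter) and so adds a direct comparison on a single substituent, which also leaves the result within the scatter.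

On these data alone, all four compounds carry a methoxy-bearing phenyl ring on the carbon with a double bond to nitrogen, so it remains open whether an unsubstituted phenyl, a saturated cyclohexyl or a pyridine ring there would leave the number equally unmoved. It is also open whether a carboxylic acid or an amine in place of the nitro group would hold to the same flat pattern, and the data shown offer no measurement that explains the pattern so far.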